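Replacing 4-methoxybenzyl on the nitrogen of compound 3

The compounds below may be only part of what the source reports. "The series", "measured", "known", "first", "only" and "open" are said of these compounds alone.

Measured so far in a functional assay on HCT-116 cells (Homo sapiens) for antiproliferative activity, read by sulforhodamine B assay, with a stated time of 72 h; on this read-out lower numbers stand for stronger inhibition and higher numbers for weaker inhibition:
- compound 1 `COc1ncc(-c2ccc3ncc(NCc4ccc(C(F)(F)F)cc4)c(OC)c3c2)cc1NS(=O)(=O)c1ccc(F)cc1F` gives 3220 nM
- compound 2 `CCNc1cnc2ccc(-c3cnc(OC)c(NS(=O)(=O)c4ccc(F)cc4F)c3)cc2c1OC` gives 1850 nM
- compound 3 `COc1ccc(CNc2cnc3ccc(-c4cnc(OC)c(NS(=O)(=O)c5ccc(F)cc5F)c4)cc3c2OC)cc1` gives 10200 nM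

Compound 3 stands highest of the three. Compound 4 `COc1ncc(-c2ccc3ncc(NC(=O)CN4CCN(C)CC4)c(OC)c3c2)cc1NS(=O)(=O)c1ccc(F)cc1F` is not yet measured and differs from it as follows: ((4-methylpiperazin-1-yl)methyl)carbonyl in place of 4-methoxybenzyl on a nitrogen on an aromatic ring. In words, ((4-methylpiperazin-1-yl)methyl)carbonyl comes in place of 4-methoxybenzyl on a nitrogen on an aromatic ring. Among the measured compounds shown here, no measured compound carries this group, so the nearest guides are a 3.2-fold higher number from compound 1 to compound 3 (0.50 log units; beyond the scatter) and a 5.5-fold higher number from compound 2 to compound 3 (0.74 log units; beyond the scatter), both modest. Compound 3 thus leaves room downward, and a modest step to a lower number is expected in this assay. The expected size is a 4.6-fold lower number from compound 3 to compound 4 (0.67 log units; beyond the scatter) and it remains an estimate. For compound 4 the estimated value is 2200 nM with an expected range from 500 nM to 9000 nM in this assay.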

Compound 4, half-maximal inhibitory concentration: 1540 nM
Estimate against measurement, compound 4: 1.4-fold (0.15 log units) above, within the range that was stated.
By their numbers in this assay, from the lowest: compounds 4, 2 and 1 (each within the scatter of the next, the first and the last beyond it); then compound 3.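

In this assay, the nitrogen on an aromatic ring accepts a carbonyl-linked group carrying a non-aromatic ring, with a 6.6-fold lower number from compound 3 to compound 4 (0.82 log units; beyond the scatter) and with a 2.1-fold lower number from compound 1 to compound 4 (0.32 log units; beyond the scatter) as the benzyl groups leave. Against the small ethyl group, the new group gives a 1.2-fold lower number from compound 2 to compound 4 (0.08 log units; within the scatter) and stays within the scatter, so a benzyl group is not needed on this nitrogen at this level of activity. No evidence here bears on the reason for these steps.

Going by these compounds, it remains open whether the carbonyl or the 4-methylpiperazine accounts for the result. An acetyl group or a morpholine-bearing acyl group on the same nitrogen would separate the two.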